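A few compounds are considered here, and "the series" means these few. Any claim that something is new, unique, unknown or untested is made for them only; others in the source may bear on it.

Measured compounds:
- compound 1, `COC(=O)/C=C(C)/C=C/CC(C)CCCC(C)C`, gives 6.2 in a physicochemical assay for lipophilicity; a higher number here means a more lipophilic compound, a lower number a more polar compound
- compound 2, `COC(=O)/C=C(C)/C=C/CC(C)CCCC(C)(C)OC`, gives 5 in this assay
- compound 3, `COC(C)(C)CCCC(C)C/C=C/C(C)=C/C(=O)OCCC(C)C`, gives 7.03 in this assay

Among these three, compound 1 stands second highest: compound 3 lies above it and compound 2 below it, both beyond the scatter. The unmeasured compound 4, `C=CCSC(=O)/C=C(C)/C=C/CC(C)CCCC(C)C`, differs from compound 1 in one place: allylsulfanyl in place of methoxy on a carbonyl carbon. Neither measured step shows this exact change. The step of a number 1.20 log units lower from compound 1 to compound 2 (beyond the scatter) adds an oxygen-containing group and lowers the number; the step of a number 2.03 log units higher from compound 2 to compound 3 (beyond the scatter) adds carbons to the group bound to the oxygen next to the carbonyl and raises the number strongly. The change from compound 1 to compound 4 also adds carbon atoms at the ester end, with sulfur entering and oxygen leaving, so the nearer guide is the step from compound 2 to compound 3. An upward step beyond the scatter is therefore expected. It is expected to be smaller than the step from compound 2 to compound 3. For compound 4 the estimated step is a number 1.20 log units higher from compound 1 to compound 4 (beyond the scatter). Compound 4 is expected to give 7.4, within a range from 6.7 to 8.1.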

Compound 4, partition coefficient: 7.97
Estimate against measurement, compound 4: 0.57 log units below; the measured number falls inside the stated range.
By their numbers in this assay, from the lowest: compound 2; then compound 1; then compound 3; then compound 4.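

In this assay, replacing methoxy with allylsulfanyl on a carbonyl carbon, which turns methoxycarbonyl into (allylsulfanyl)carbonyl, gives a number 1.77 log units higher from compound 1 to compound 4 (beyond the scatter). The earlier change at this end of the molecule kept the oxygen and added carbons to the group on it, giving a number 2.03 log units higher from compound 2 to compound 3 (beyond the scatter), whereas this new pair shows a large rise in the number when that oxygen leaves and a sulfur enters along with the allyl chain. Because the swap brings in sulfur, extra carbons and a double bond all at once, this single pair cannot show how much each part contributes, and nothing available here explains the rise.

The compounds shown leave open where propylsulfanyl, which has the same chain length without the double bond, or methylsulfanyl, which keeps the sulfur with a single carbon, would fall in this assay. They also leave open whether allylsulfanyl would give a similar step on compound 2, and how an amine-derived amide at the same carbonyl carbon would compare.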